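Ethoxy in place of hydroxy on compound 1

A few compounds are considered here, and "the series" means these few. Any claim that something is new, unique, unknown or untested is made for them only; others in the source may bear on it.

Compound 1 `N#Cc1ncc2nc1OCC/C=C\COc1ccc(O)cc1NC(=O)N2` has been tested in a functional assay on NCI-H1299 cells (Homo sapiens), read by flow cytometry; a lower number here means that less compound is needed, a higher number that more compound is needed for the effect. There, compound 1 gives > 10000 nM, which is a limit and not a number. Compound 2 `N#Cc1ncc2nc1OC/C=C\COc1ccc(Cl)cc1NC(=O)N2` gives > 10000 nM, which is also a limit. For the measured compounds named here, the series therefore offers only (the limit of > 10000 nM in this assay, at which 2 of the 2 values shown sit), and no measured step is available for calibration.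

Compound 3 `CCOc1ccc2c(c1)NC(=O)Nc1cnc(C#N)c(n1)OCC/C=C\CO2` differs from compound 1 by one change: ethyl in place of hydrogen on an oxygen on an aromatic ring, that is, hydroxy to ethoxy. With compound 1 at the limit > 10000 nM as the only anchor, little more than a small move towards less compound needed can be expected, and a reading that stays at the limit would be about as likely. The estimated change is an at least 1.4-fold lower number from compound 1 to compound 3 (0.15 log units; that floor lies within the scatter). The expected value for compound 3 is 7000 nM, with an estimated range of 1500 nM to 20000 nM.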

Compound 3, half-maximal effective concentration: > 10000 nM
Compound 3 gave a limit, no number; the forecaster's own chance of this, stated with the estimate: 50%; middle value at least 1.4-fold (0.15 log units) away from the limit.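

Compound 1 and compound 3 differ by hydroxy to ethoxy, yet no step can be read between them, as both values are limits and not numbers: the limit of > 10000 nM in this assay, at which 3 of the 3 values shown sit.

The compounds shown leave open how much of any of them is needed for the effect, and whether hydroxy to ethoxy changes that amount.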